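Cyclohexyl to benzyl swap at an aromatic nitrogen

The compounds below may be only part of what the source reports. "The series", "measured", "known", "first", "only" and "open" are said of these compounds alone.

Three compounds of the series carry a number in a functional assay on OVCAR-3 cells (Homo sapiens) for inhibition, read by sulforhodamine B assay, with a stated time of 48 h, tested at 10 uM; on this read-out higher numbers stand for more inhibition at the one concentration tested (going by the name of the read-out) and lower numbers for less inhibition. Compound 1 `c1ccc2c(-c3cn4ccnc4c(-c4ccc5ncn(C6CCCCC6)c5c4)n3)cccc2c1` gives 2.38% in this assay. Compound 2 `c1ccc(Cn2cnc3ccc(-c4nc(-c5cccc6ccccc56)cn5ccnc45)cc32)cc1` is built from the same core and shows benzyl in place of cyclohexyl on an aromatic nitrogen relative to compound 1; in this assay compound 2 gives 1.44%. The measured step for this change is a number 0.9 percentage points lower from compound 1 to compound 2 (within the scatter), so the two values cannot be told apart. Compound 3 `c1cn2cc(-c3ccc4c(c3)ncn4C3CCCCC3)nc(-c3ccc4ncn(C5CCCCC5)c4c3)c2n1` gives 3.05% in this assay; how its core differs from the core of compound 1 is not broken down here, and its value and those of compound 1 and compound 2 lie within the scatter of one another, so no order among the three is claimed.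

Compound 4 `c1ccc(Cn2cnc3ccc(-c4nc(-c5ccc6c(c5)ncn6C5CCCCC5)cn5ccnc45)cc32)cc1` has not yet been measured. It differs from compound 3 by benzyl in place of cyclohexyl on an aromatic nitrogen, and the place is described in the same words as for the pair of compound 1 and compound 2, so this is the same change made on the core of compound 3. On the assumption that it behaves as the measured pair did, the step from compound 3 is expected to be a number 0.9 percentage points lower from compound 3 to compound 4 (within the scatter), a size resting on the observed step of a number 0.9 percentage points lower from compound 1 to compound 2 (within the scatter). For compound 4 the estimated value in this assay is 2.2%, with a range from -6% to 10% reflecting the usual scatter of a single-concentration read-out.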

Compound 4, a percentage reported as inhibition, at one concentration (the size of the read-out at that concentration, not a potency): -35.7%
The estimate for compound 4 lay 37.9 percentage points above the measured number; measured number below the stated range.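

In this assay the swap of cyclohexyl for benzyl on the aromatic nitrogen does not carry over at a fixed size, with the step on the core of compound 3 reading a number 38.8 percentage points lower from compound 3 to compound 4 (beyond the scatter), and the two steps differ: the same change on two cores in this assay, a number 0.9 percentage points lower (within the scatter) from compound 1 to compound 2 and a number 38.8 percentage points lower (beyond the scatter) from compound 3 to compound 4, 37.8 percentage points apart, beyond the scatter of two such steps The step seen on the core of compound 1 therefore gave no reliable guide to the step on the core of compound 3, so in these two pairs the outcome of the change depends on the core that carries it. This does not show which feature of the cores sets the difference, why compound 4 gives -35.7%, a negative number on an inhibition read-out, or that any other core would follow either pair, as two pairs at one concentration support no general rule.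

The compounds shown carry only cyclohexyl and benzyl on this aromatic nitrogen, so it remains open how the result would look with a longer alkyl chain there, or with a chain ending in an amine or a carboxylic acid. As far as these compounds go, it also remains open whether such groups would give steps that differ between the two cores in the same way.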